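Second chloro on the aryl hydrazone: compound 4

The source may report more compounds than this note shows. Statements on the series, on what has been measured and on what is new or still open speak of the compounds shown alone.

Measured compounds:
compound 1, `Cn1nnnc1SCC(=O)N/N=C/c1cccc([N+](=O)[O-])c1`: > 10000000 nM in a functional assay on A549 cells (Homo sapiens) for cytotoxicity, read by XTT assay, with a stated time of 24 h; a lower number here means a stronger inhibitor, a higher number a weaker inhibitor (a limit)
compound 2, `Cn1nnnc1SCC(=O)N/N=C/c1ccccc1Cl`: 6320000 nM
compound 3, `Cn1nnnc1SCC(=O)N/N=C/c1cccc(Cl)c1`: 7500000 nM

In this assay compound 1 reaches only a limit, > 10000000 nM. Compound 2 gives 6320000 nM. Compound 3 gives 7500000 nM; its value and that of compound 2 lie within the scatter of each other, so no order between the two is claimed. Compound 3 thus holds the highest of the two numbers, and the remaining value in the set is a limit. Among the measured compounds shown here, the only single-point step measured is an at least 1.3-fold lower number from compound 1 to compound 3 (0.12 log units; that floor lies within the scatter), which itself sits within the scatter and is capped by the limit of > 10000000 nM in this assay, at which 1 of the 3 values shown sits.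

Compound 4, `Cn1nnnc1SCC(=O)N/N=C/c1cccc(Cl)c1Cl`, differs from compound 3 by chloro in place of hydrogen on an aromatic carbon. For the measured compounds named here, no measured step adds a chloro to a ring already bearing one, so the step to compound 4 rests on no direct precedent; the step from compound 1 to compound 3 shows only that swapping the substituent on this ring moved the number little. For compound 4 a step of a 1.5-fold lower number from compound 3 to compound 4 (0.18 log units; within the scatter) in this assay is therefore expected, most likely within the scatter, with a slight lean toward a lower number. Compound 4 is estimated at 5000000 nM, between 1500000 nM and 15000000 nM.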

Compound 4, half-maximal inhibitory concentration: 632000 nM
Compound 4: middle estimate off by 7.9-fold (0.90 log units), on the high side; measured number below the stated range.
By their numbers in this assay, from the lowest: compound 4; then compounds 2 and 3 (each within the scatter of the next). At a limit, above all of these: compound 1.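

In this assay, among the compounds shown here, the second chloro gives a 12-fold lower number from compound 3 to compound 4 (1.07 log units; beyond the scatter) and a 10-fold lower number from compound 2 to compound 4 (1.00 log units; beyond the scatter), the first steps that are printed as beyond the scatter. Compounds 2 and 3, each with a single chloro, lie within the scatter of each other, so the ring position of one chloro did not separate them, whereas a chloro ortho to a chloro group does. Both steps are the same change, chloro in place of hydrogen on an aromatic carbon, and among these compounds the lower number appears only with both chloro groups present.

Compound 1 remains a limit, so its distance from compound 4 stays unread: the limit of > 10000000 nM in this assay, at which 1 of the 4 values shown sits.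
Open too, on these data alone, is whether a bromo, a methoxy or an amine at this position would give a step of like size, or whether it is specific to chloro.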